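A few compounds are considered here, and "the series" means these few. Any claim that something is new, unique, unknown or untested is made for them only; others in the source may bear on it.

Compound 1 `CN1CCN(c2ncc(-c3ccc4c(N[C@@H]5CCCC[C@H]5O)ccnc4c3)cn2)CC1` and compound 2 `CN1CCN(c2ncc(-c3ccc4c(NC5CCC(N(C)C)CC5)ccnc4c3)cn2)CC1` share one core and differ only in the group on a nitrogen on an aromatic ring. In an ADME assay on HepG2 cells (Homo sapiens) for cytotoxicity, read by MTT assay, with a stated time of 48 h (on this read-out lower numbers stand for higher toxicity in this test and higher numbers for lower toxicity in this test), compound 1 gives > 3.6 uM, which is a limit of the assay rather than a number. In this assay compound 2 gives 2.5 uM. Putting 4-(dimethylamino)cyclohexyl in place of 2-hydroxycyclohexyl gave an at least 1.4-fold lower number from compound 1 to compound 2 (0.15 log units; that floor lies within the scatter). Among the measured compounds shown here, compound 2 thus holds the only plain number so far, while the other value is a limit, as the limit of > 3.6 uM in this assay, at which 1 of the 2 values shown sits, shows. Compound 3 `CN1CCN(c2ncc(-c3ccc4c(NC5CCOCC5)ccnc4c3)cn2)CC1` alters the same position once more: oxan-4-yl in place of 4-(dimethylamino)cyclohexyl on a nitrogen on an aromatic ring. For the measured compounds named here, the single measured step bears on this only as a change at that same place, and its floor sits within the scatter, so it settles no direction. No step beyond the scatter is expected here. The expected step is a 1.4-fold higher number from compound 2 to compound 3 (0.15 log units; within the scatter). The estimate for compound 3 is 3.5 uM, ranging from 1.3 uM to 10 uM.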

Compound 3, half-maximal toxic concentration: 15 uM
Estimate against measurement, compound 3: 4.3-fold (0.63 log units) below; the measured number lies above the stated range.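

In this assay, this position now shows a step beyond the usual scatter, which the first pair could not show: oxan-4-yl in place of 4-(dimethylamino)cyclohexyl gave a 6.0-fold higher number from compound 2 to compound 3 (0.78 log units; beyond the scatter). On this read-out a higher number stands for lower toxicity in the test, so the group on this nitrogen can clearly shift the result. Compound 1 stands at a limit of the assay and not at a number, so its step to compound 3 cannot be read: the limit of > 3.6 uM in this assay, at which 1 of the 3 values shown sits.

The change from compound 2 to compound 3 removes the dimethylamino group and brings an oxygen into the ring in a single swap, so the compounds shown cannot say which of the two goes with the higher number. A plain cyclohexyl group on the same nitrogen, with neither the amine nor the oxygen, would help to separate them.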